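The source may report more compounds than this note shows. Statements on the series, on what has been measured and on what is new or still open speak of the compounds shown alone.

Measured so far:
compound 1, `CS(=O)(=O)CCCn1c(Cn2nc(S(C)(=O)=O)c3ccccc32)nc2cc(Cl)ccc21`: > 100000 nM in an ADME assay on HEp-2 cells (Homo sapiens) for cytotoxicity, with a stated time of 4 days; on this read-out lower numbers stand for higher toxicity in this test and higher numbers for lower toxicity in this test
compound 2, `CC(C)(O)CCCn1c(Cn2nc(S(C)(=O)=O)c3ccncc32)nc2cc(Cl)ccc21`: > 100000 nM in this assay

Both readings are limits of this assay and not numbers. For compound 1 the reading > 100000 nM is a limit. Among the compounds with values here, for compound 2 the reading > 100000 nM is likewise a limit, so compound 2 stands at the ceiling of what this assay reports, alongside the only other value. Within the data shown here, what the series shows so far is summed up by the limit of > 100000 nM in this assay, at which 2 of the 2 values shown sit, and no step between measured compounds can be read from it.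

Compound 3, `CS(=O)(=O)c1nn(Cc2nc3cc(Cl)ccc3n2CCCCC(F)(F)F)c2cnccc12`, differs from compound 2 by 2,2,2-trifluoroethyl in place of 1-hydroxy-1-methylethyl on a saturated chain carbon, three bonds along the chain from an aromatic nitrogen. Among the measured compounds shown here, with no measured step to lean on, the expectation for compound 3 in this assay is no step beyond the scatter, the reading most probably coming out again as a limit. Compound 3 is estimated at 100000 nM, within a range of 30000 nM to 300000 nM. That estimate corresponds to a step of a number no higher from compound 2 to compound 3 (the limit leaves the size open), which is expected to amount to none beyond the scatter.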

Compound 3, half-maximal cytotoxic concentration: > 100000 nM
Compound 3 gave a limit, no number (the forecaster's own chance of this, stated with the estimate: 80%); the middle value lies on the limit itself.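

Compound 2 and compound 3 both read as limits and not numbers in this assay, so no new step between them can be read: the limit of > 100000 nM in this assay, at which 3 of the 3 values shown sit.

Left open is whether compound 1, compound 2 or compound 3 would give an actual number in this assay, and whether 2,2,2-trifluoroethyl in place of 1-hydroxy-1-methylethyl makes any difference there.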